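A few compounds are considered here, and "the series" means these few. Any claim that something is new, unique, unknown or untested is made for them only; others in the source may bear on it.

Measured so far:
compound 1 `CCCNC(=O)c1cc(Oc2ccc(NC(=O)c3cc4cccnc4n(-c4ccc(F)cc4)c3=O)cc2)ccn1` — in a functional assay on U-87MG ATCC cells for antiproliferative activity against U-87 MG (Homo sapiens), read by MTT assay, with a stated time of 72 h (on this read-out higher numbers stand for weaker inhibition and lower numbers for stronger inhibition), compound 1 gives 960 nM.
compound 2 `CCCNC(=O)c1cc(Oc2ccc(NC(=O)c3cc4cccnc4n(-c4ccc(Cl)cc4)c3=O)cc2)ccn1` — in this assay compound 2 gives "not determined" (no result reported).

Compound 2 therefore stands nowhere on the numbers shown; only compound 1 carries a value. Compound 3 `CCCNC(=O)c1cc(Oc2ccc(NC(=O)c3cc4cccnc4n(-c4ccc(C(F)(F)F)cc4Cl)c3=O)cc2)ccn1` differs from compound 2 by 2-chloro-4-(trifluoromethyl)phenyl in place of 4-chlorophenyl on an aromatic nitrogen. Among the compounds with values here, no step between measured compounds is recorded, so the size and direction of the change in this assay are open; with compound 1 at 960 nM as the only anchor, compound 3 is expected to land near that level, any shift probably within the scatter. The estimate for compound 3 is 1000 nM, within 200 nM to 5000 nM.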

Compound 3, half-maximal inhibitory concentration: 10900 nM
Compound 3: middle estimate off by 11-fold (1.04 log units), on the low side, and the stated range ends below it.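

In this assay, 2-chloro-4-(trifluoromethyl)phenyl in place of 4-fluorophenyl on the aromatic nitrogen gives an 11-fold higher number from compound 1 to compound 3 (1.06 log units; beyond the scatter), so the group at this position can move this read-out well beyond the scatter. The step to compound 3 from compound 2 cannot be read, as compound 2 has no number. Nothing measured here offers a reason for the shift. Still open, as far as these compounds go, is whether the chlorine or the trifluoromethyl of the entering group accounts for the shift, as both arrive together. From the compounds shown here alone, how a methoxy group or an amine on this ring would read also remains open.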